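Swapping a fluorophenyl for a pyridyl on the amide

A few compounds are considered here, and "the series" means these few. Any claim that something is new, unique, unknown or untested is made for them only; others in the source may bear on it.

Compound 1, `CCCNC(=O)c1nc(-c2cccs2)[nH]c(=O)c1O`: in an assay on isolated protein for inhibition of deoxyribonuclease-1 (Homo sapiens) (on this read-out lower numbers stand for stronger inhibition and higher numbers for weaker inhibition), compound 1 gives > 100000 nM, which is a limit of the assay rather than a number.
Compound 2, `CCC(C)NC(=O)c1nc(-c2cccs2)[nH]c(=O)c1O`: in this assay compound 2 gives > 100000 nM, again a limit and not a number.
Compound 3, `O=C(Nc1ccc(F)cc1)c1nc(-c2cccs2)[nH]c(=O)c1O`: in this assay compound 3 gives "not determined" (no result reported), that is, no result was reported for compound 3.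

Compound 3 therefore stands nowhere on the numbers shown: the only two values reported sit at the limit described by the limit of > 100000 nM in this assay, at which 2 of the 3 values shown sit, and compound 3 itself has none. The move to compound 4, `O=C(Nc1cccnc1)c1nc(-c2cccs2)[nH]c(=O)c1O`, replaces (pyridin-3-yl in place of 4-fluorophenyl on an amide-type nitrogen). Among the measured compounds shown here, the one measured step, a step that the two limits leave unreadable from compound 1 to compound 2, cannot be read because both of its values are limits, and it concerns the chain on the amide nitrogen rather than an aromatic ring, so no measured step bears on the present change. No size or direction can be expected in this assay from the data; the only hint is that both reported values reach the limit. Compound 4 is therefore estimated at 100000 nM, with a range from 20000 nM to 300000 nM, and most likely only a limit will be reported.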

Compound 4, half-maximal inhibitory concentration: > 100000 nM
Compound 4: only a limit was reported; the forecaster's own chance of this, stated with the estimate: 70%; the middle value lies on the limit itself.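

No new step can be read: compound 4, like compound 1 and compound 2, gives only a limit, so the steps joining them stay unreadable: the limit of > 100000 nM in this assay, at which 3 of the 4 values shown sit.

The compounds shown leave open whether changing the group on the amide nitrogen alters inhibition in this assay at all, and how compound 3 compares with compound 4.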